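A few compounds are considered here, and "the series" means these few. Any claim that something is new, unique, unknown or untested is made for them only; others in the source may bear on it.

Measured in a functional assay on MCF7 cells (Homo sapiens) for cytotoxicity, read by MTT assay, with a stated time of 24 h; a lower number here means a stronger inhibitor, a higher number a weaker inhibitor:
- compound 1 `COc1ccc(/C=C(\C#N)C(=O)N/N=C(\C)c2c(O)c3ccc(O)cc3oc2=O)cc1OC`: 14400 nM
- compound 2 `COc1cc(/C=C(\C#N)C(=O)N/N=C(\C)c2c(O)c3ccc(O)cc3oc2=O)cc(OC)c1OC`: 11300 nM
- compound 3 `C/C(=N\NC(=O)/C(C#N)=C/c1ccc(Br)cc1)c1c(O)c2ccc(O)cc2oc1=O`: 9850 nM

Compound 3, at 9850 nM, lies within the scatter of both other compounds, so the three values form one band. Compound 4 `C/C(=N\NC(=O)/C(C#N)=C/c1ccccc1[N+](=O)[O-])c1c(O)c2ccc(O)cc2oc1=O` carries a new group at the same place: 2-nitrophenyl in place of 4-bromophenyl on a double-bonded chain carbon bound to a double-bonded chain carbon. The closest measured change, also on this carbon, is a 1.5-fold lower number from compound 1 to compound 3 (0.16 log units; within the scatter). On the aromatic ring, the other measured change is a 1.3-fold lower number from compound 1 to compound 2 (0.11 log units; within the scatter). Among the compounds with values here, neither step leaves the scatter, though no compound with 2-nitrophenyl has been measured. In this assay, no step beyond the scatter is therefore expected. The estimated change is a 1.0-fold higher number from compound 3 to compound 4 (0.01 log units; within the scatter). The expected value for compound 4 is 10000 nM, with an estimated range of 4500 nM to 22000 nM.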

Compound 4, half-maximal inhibitory concentration: 9180 nM
Compound 4: middle estimate off by 1.1-fold (0.04 log units), on the high side, within the range that was stated.
By their numbers in this assay, from the lowest: compounds 4, 3, 2 and 1 (each within the scatter of the next).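

In this assay, 2-nitrophenyl on this double-bonded chain carbon gives a 1.1-fold lower number from compound 3 to compound 4 (0.03 log units; within the scatter) and, against the other aryl group, a 1.6-fold lower number from compound 1 to compound 4 (0.20 log units; within the scatter), so both steps to the new group stay inside the one band. The hydrogen-bond acceptors and additional heavy atoms that enter with 2-nitrophenyl therefore come with no step beyond the scatter at this place. No measurement here accounts for this flat result. Still open, as far as these compounds go, is whether an amine, a carboxylic acid or a longer alkyl chain at this carbon would leave the band.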